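Replacing the Sulfonamide of Compound 3 with a Carboxylic Acid

This account rests on a few compounds, and the source may have more. Where it says the series, first, only, none or still open, it means among the compounds named here.

Compound 1, `CCCNc1cccnc1-c1ccc(C(=O)Nc2ccc(C(C)(C)C)cc2)cc1`: in a functional assay for antagonist activity at transient receptor potential cation channel subfamily V member 1 (Homo sapiens), read by FLIPR (on this read-out higher numbers stand for weaker inhibition and lower numbers for stronger inhibition), compound 1 gives 158 nM.
Compound 2, `CCS(=O)(=O)Nc1cccnc1-c1ccc(C(=O)Nc2ccc(C(C)(C)C)cc2)cc1`: in this assay compound 2 gives 49 nM.
Compound 3, `CC(C)(C)c1ccc(NC(=O)c2ccc(-c3ncccc3NS(=O)(=O)c3ccccc3)cc2)cc1`: in this assay compound 3 gives 91 nM.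

Compound 3 holds the second highest of the three numbers. Its nearest neighbour is compound 1, separated by a 1.7-fold lower number from compound 1 to compound 3 (0.24 log units; within the scatter), and its furthest is compound 2, separated by a 1.9-fold higher number from compound 2 to compound 3 (0.27 log units; within the scatter); both gaps sit within the scatter, so the three compounds cannot be ordered.

Compound 4, `CC(C)(C)c1ccc(NC(=O)c2ccc(-c3ncccc3C(=O)O)cc2)cc1`, differs from compound 3 in one place: carboxy in place of (phenylsulfonyl)amino on an aromatic carbon. Going by the values given here, every measured step so far, a 3.2-fold lower number from compound 1 to compound 2 (0.51 log units; beyond the scatter), a 1.7-fold lower number from compound 1 to compound 3 (0.24 log units; within the scatter) and a 1.9-fold higher number from compound 2 to compound 3 (0.27 log units; within the scatter), only exchanged what hangs on the ring nitrogen or on the sulfonyl sulfur; none removed that whole group or put in a carboxy. Among the compounds with values here, no measured step therefore bears directly on this change. In the absence of a guide, compound 4 is expected to give a higher number in this assay than compound 3, and the estimate is uncertain.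

Compound 4 is expected to give about 2000 nM, within a range from 300 nM to 20000 nM. This estimate is expected to correspond to a step of a 22-fold higher number from compound 3 to compound 4 (1.34 log units; beyond the scatter).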

Compound 4, half-maximal inhibitory concentration: > 4000 nM
Compound 4 ended at the assay's limit; the forecaster's own chance of this, stated with the estimate: 25%; middle value at least 2.0-fold (0.30 log units) away from the limit.
By their numbers in this assay, from the lowest: compounds 2, 3 and 1 (each within the scatter of the next, the first and the last beyond it). At a limit, above all of these: compound 4.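

Compound 4 stands at a limit of this assay, so its value is a limit and not an exact number: the limit of > 4000 nM in this assay, at which 1 of the 4 values shown sits.

Among the earlier compounds, the largest step was a 3.2-fold lower number from compound 1 to compound 2 (0.51 log units; beyond the scatter), whereas placing carboxy on this aromatic carbon gives an at least 43-fold higher number from compound 3 to compound 4 (1.64 log units; beyond the scatter), an at least 81-fold higher number from compound 2 to compound 4 (1.91 log units; beyond the scatter) and an at least 25-fold higher number from compound 1 to compound 4 (1.40 log units; beyond the scatter). Going by these compounds alone, this position therefore accepts the propylamino, (ethylsulfonyl)amino and (phenylsulfonyl)amino groups of compounds 1, 2 and 3, but inhibition is largely lost with the carboxy of compound 4, the only group here attached through carbon rather than nitrogen.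

From the compounds shown here alone, how far the true value of compound 4 lies past the limit remains open. Also open, going by these compounds, is whether the loss goes with the carboxylic acid itself or with the missing nitrogen link, a question that a primary carboxamide or a methyl ester on this carbon would address.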